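Adding Cyclohexyl to the Amino Nitrogen of Compound 2

The source may hold more compounds than are shown below. What is called first, only, known or untested is meant among the compounds shown, and "the series" means these compounds.

In an ADME assay on a cell-free system (serum) for metabolic stability (on this read-out lower numbers stand for a shorter-lived compound and higher numbers for a longer-lived compound), compound 1 (`C=CCOc1ccc(NC(=O)c2ccc(Cl)cc2Cl)cc1C(C)(C)C`) gives > 1 h as its result, which is a limit of the assay and not a number. Compound 2 (`CC(C)(C)c1cc(NC(=O)c2c(Cl)cc(N)cc2Cl)ccc1O`) gives > 1 h as its result, again a limit and not a number. Compound 2 therefore offers no exact half-life as a starting point. Compound 3 (`CC(C)(C)c1cc(NC(=O)c2c(Cl)cc(NC3CCCCC3)cc2Cl)ccc1O`) differs from compound 2 in one place (cyclohexyl in place of hydrogen on a nitrogen on an aromatic ring): cyclohexyl in place of hydrogen on a nitrogen on an aromatic ring, turning amino into cyclohexylamino. In this assay, among the measured compounds shown here, no measured pair shows what such a change does, so no shift beyond the usual scatter is expected in either direction. The expected move (a step that the limit leaves unreadable from compound 2 to compound 3) is therefore small. Compound 3 is expected at 1.5 h within an estimated range of 0.7 h to 5 h. Its result may again turn out to be only a limit.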

Compound 3, half-life: > 1 h
Compound 3 was reported as a limit; the forecaster's own chance of this, stated with the estimate: 75%; the middle value is on the limit's open side.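

In this assay, compound 2 and compound 3 both give a limit and not a number, so no step between them can be read: the limit of > 1 h in this assay, at which 3 of the 3 values shown sit.

The compounds shown leave open whether cyclohexyl in place of hydrogen on the nitrogen changes the half-life at all, and by how much.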